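Ethylcarbamoyl piperazine dithiocarbamates: three limits and one open case

The compounds below may be only part of what the source reports. "The series", "measured", "known", "first", "only" and "open" are said of these compounds alone.

Compound 1 `COc1ccc(Cn2cc(CSC(=S)N3CCN(C(N)=O)CC3)nn2)cc1`: in a functional assay on SMMC-7721 cells (Homo sapiens) for cytotoxicity, read by MTT assay, with a stated time of 72 h (on this read-out lower numbers stand for stronger inhibition and higher numbers for weaker inhibition), compound 1 gives only a limit, > 128000 nM.
Compound 2 `CCNC(=O)N1CCN(C(=S)SCc2cn(Cc3ccc(OC)cc3)nn2)CC1`: in this assay compound 2 likewise gives only a limit, > 128000 nM.
Compound 3 `COc1cc(Cn2cc(CSC(=S)N3CCN(C(N)=O)CC3)nn2)cc(OC)c1OC`: in this assay compound 3 also gives only a limit, > 128000 nM.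

All three measured values sit at the same limit, (the limit of > 128000 nM in this assay, at which 3 of the 3 values shown sit), so none of the three can be placed in order against the others. The change from compound 1 to compound 2 is ethyl in place of hydrogen on an amide-type nitrogen; its step in this assay, a step that the two limits leave unreadable from compound 1 to compound 2, cannot be read because both values are limits. The difference between the core of compound 1 and the core of compound 3 is not broken down here.

Compound 4 `CCNC(=O)N1CCN(C(=S)SCc2cn(Cc3cc(OC)c(OC)c(OC)c3)nn2)CC1` is not yet measured. It differs from compound 3 by ethyl in place of hydrogen on an amide-type nitrogen, the same change that leads from compound 1 to compound 2, made at the same kind of place. Since compound 1 and compound 2 both stopped at the limit of > 128000 nM in this assay, at which 3 of the 3 values shown sit, compound 4 is expected to do the same, with an estimated step that the limit leaves unreadable from compound 3 to compound 4. For compound 4 the estimated value is 200000 nM, expected to fall between 100000 nM and 600000 nM.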

Compound 4, half-maximal inhibitory concentration: > 128000 nM
Compound 4: only a limit was reported; the forecaster's own chance of this, stated with the estimate: 85%; the middle value lies beyond the limit too.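

Compound 3 and compound 4 both give only a limit, so no new step can be read for ethyl in place of hydrogen on an amide-type nitrogen: the limit of > 128000 nM in this assay, at which 4 of the 4 values shown sit. The compounds shown leave open how strongly any of them inhibits these cells, and whether this change alters the read-out at all.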